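Carbamate chain extension and microsomal half-life in the thiophene sulfonylcarbamate series

A few compounds are considered here, and "the series" means these few. Any claim that something is new, unique, unknown or untested is made for them only; others in the source may bear on it.

Measured compounds in an ADME assay on microsomes from liver (Homo sapiens) for metabolic stability, read by LC-MS, using NADPH, tested at 1 uM; on this read-out lower numbers stand for a shorter-lived compound and higher numbers for a longer-lived compound:
- compound 1 `COC(=O)NS(=O)(=O)c1sc(CC(C)C)cc1-c1cccc(Cn2ccnc2)c1`: 1.28 h
- compound 2 `CCCCCOC(=O)NS(=O)(=O)c1sc(CC(C)C)cc1-c1cccc(Cn2ccnc2)c1`: 0.108 h
- compound 3 `CC(C)CCOC(=O)NS(=O)(=O)c1sc(CC(C)C)cc1-c1cccc(Cn2ccnc2)c1`: 0.0817 h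

Compound 1 gives the highest number of the three; the nearest is compound 2, a 12-fold lower number from compound 1 to compound 2 (1.07 log units; beyond the scatter), and the furthest is compound 3, a 16-fold lower number from compound 1 to compound 3 (1.19 log units; beyond the scatter). Between the two longer chains the gap is small, a 1.3-fold lower number from compound 2 to compound 3 (0.12 log units; within the scatter).

Compound 4 `COCCOC(=O)NS(=O)(=O)c1sc(CC(C)C)cc1-c1cccc(Cn2ccnc2)c1` is not yet measured. Against compound 1 the change is methoxymethyl in place of hydrogen on a saturated chain carbon bound to an oxygen next to a carbonyl group. Among the compounds with values here, two measured steps bear on it, both at the same place of the core of compound 1 and both large: the step to compound 2 and the step to compound 3, each a clear fall in half-life. Compound 4 carries a shorter chain than either, with an oxygen in it, so the same direction is expected but perhaps a smaller size. For compound 4 the step is estimated as a 4.3-fold lower number from compound 1 to compound 4 (0.63 log units; beyond the scatter). The expected value for compound 4 in this assay is 0.3 h, in the range 0.1 h to 0.9 h.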

Compound 4, half-life: 0.45 h
Estimate against measurement, compound 4: 1.5-fold (0.18 log units) below; low and high end bracket the measured number.
By their numbers in this assay, from the lowest: compounds 3 and 2 (each within the scatter of the next); then compound 4; then compound 1.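

Within the data shown here, at this place, the ether oxygen separates chains that the earlier compounds left unresolved: in this assay, methoxy in place of propyl gives a 4.2-fold higher number from compound 2 to compound 4 (0.62 log units; beyond the scatter), and methoxy in place of isopropyl gives a 5.5-fold higher number from compound 3 to compound 4 (0.74 log units; beyond the scatter). Extension from the methyl carbamate therefore does not carry one fixed cost, although the 2-methoxyethyl chain still gives a 2.8-fold lower number from compound 1 to compound 4 (0.45 log units; beyond the scatter), a modest step against the large 12-fold lower number from compound 1 to compound 2 (1.07 log units; beyond the scatter). Nothing available gives a reason for these differences.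

On these data alone, it remains open how a 2-hydroxyethyl or 2-aminoethyl chain, or a longer chain holding an ether oxygen, would compare with compound 4. An ethyl carbamate would also show how far a short chain without oxygen falls from compound 1.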